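A Sulfonyl Aryl Exchange Tested for Cytotoxicity

This account rests on a few compounds, and the source may have more. Where it says the series, first, only, none or still open, it means among the compounds named here.

In an ADME assay on HCT-116 cells (Homo sapiens) for cytotoxicity, read by CellTiter-Glo, with a stated time of 72 h (a higher number here means a weaker inhibitor, a lower number a stronger inhibitor), compound 1 `CC1CCN(C2CCN(S(=O)(=O)c3cccnc3Cl)CC2)CC1` gives only the limit > 10000 nM and no number. Compound 2 `Cc1cc(C)c(S(=O)(=O)N2CCC(c3ccccc3)CC2)c(C)c1` likewise reaches only the limit > 5000 nM. Compound 3 `CC1CCN(C2CCN(S(=O)(=O)c3cccc4cnccc34)CC2)CC1` also stops at the limit > 10000 nM. All three values shown are therefore limits, the limit of > 10000 nM in this assay, at which 2 of the 3 values shown sit, and (the limit of > 5000 nM in this assay, at which 1 of the 3 values shown sits), and none of them is a measured number. Compound 4 `CC1CCN(C2CCN(S(=O)(=O)c3ccc(F)cc3F)CC2)CC1` differs from compound 1 by 2,4-difluorophenyl in place of 2-chloropyridin-3-yl on a sulfonyl sulfur. Among the compounds with values here, no step between measured compounds is known, so the size of this change in this assay cannot be drawn from the data; the expectation is for no movement beyond the scatter. Compound 4 is estimated at 15000 nM, between 5000 nM and 50000 nM. The step that the limit leaves unreadable from compound 1 to compound 4 that this estimate implies is expected to be none beyond the scatter.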

Compound 4, half-maximal inhibitory concentration: > 5000 nM
Compound 4: no number, only a limit; the forecaster's own chance of this, stated with the estimate: 85%; the middle value is on the limit's open side.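

Within the data shown here, compound 1 and compound 4 both stop at limits in this assay, so no step between them can be read. The compounds shown leave open whether 2,4-difluorophenyl in place of 2-chloropyridin-3-yl on a sulfonyl sulfur shifts the half-maximal inhibitory concentration at all.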